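This account rests on a few compounds, and the source may have more. Where it says the series, first, only, none or still open, it means among the compounds named here.

Measured compounds:
compound 1 `COc1cc2c(c(OC)c1OC)C(=O)[C@]1(OC)C=C[C@H]2N(C(=O)OCC(C)C)N1C(=O)OCC(C)C` gives > 300 ug/mL
compound 2 `COC(=O)N1[C@@H]2C=C[C@@](OC)(C(=O)c3c2cc(OC)c(OC)c3OCc2ccccc2F)N1C(=O)OC` gives 137 ug/mL

Of the compounds shown here, two have been tested in an ADME assay on KB cells (Homo sapiens) for cytotoxicity; a higher number here means that more compound is needed for the effect, a lower number that less compound is needed. For compound 1 the result is a limit of the assay and not a number, as its value > 300 ug/mL shows. Compound 2 gives 137 ug/mL, a measured number within the range of this assay. Going by the values given here, no pair of measured compounds differs in only one place, so no single measured step stands behind the comparison of these two.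

Compound 3 `COc1ccc(COc2c(OC)c(OC)cc3c2C(=O)[C@]2(OC)C=C[C@H]3N(C(=O)OCC(C)C)N2C(=O)OCC(C)C)cc1` has not yet been measured in this assay. It differs from compound 1 in one place: 4-methoxyphenyl in place of hydrogen on a saturated chain carbon bound to an oxygen on an aromatic ring. Compound 1 sits at the limit (the limit of > 300 ug/mL in this assay, at which 1 of the 2 values shown sits), which leaves only one side of the range to move into. The step from compound 1 to compound 3 in this assay is expected to run toward a lower number, and to lie beyond the usual scatter, as an at least 2.0-fold lower number from compound 1 to compound 3 (0.30 log units; that floor lies within the scatter) states, though with wide uncertainty. Compound 3 is estimated at 150 ug/mL, with a likely range from 50 ug/mL to 300 ug/mL.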

Compound 3, concentration for half-maximal effect: 47.9 ug/mL
The estimate for compound 3 lay 3.1-fold (0.50 log units) above the measured number, and the stated range ends above it.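

Placing 4-methoxyphenyl in place of hydrogen on a saturated chain carbon bound to an oxygen on an aromatic ring gives, in this assay, an at least 6.2-fold lower number from compound 1 to compound 3 (0.79 log units; beyond the scatter), which shows that a change at this position can move the read-out beyond the usual scatter, toward less compound being needed for the effect. Compound 1 gives > 300 ug/mL, which is a limit of the assay and not a number. The step is therefore a floor, and its true size stays unknown because compound 1 stands at that limit: the limit of > 300 ug/mL in this assay, at which 1 of the 3 values shown sits.

With a single change at this position, the compounds shown cannot tell whether the step belongs to the aromatic ring itself or to the methoxy on it, and a plain benzyl, a longer chain or an amine in the same place would be needed to separate these readings. They also leave open whether the same change would give a step of this kind on a core carrying other groups, such as a carboxylic acid, in place of the two isobutyl carbamates kept here.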